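A Methyl Added to an Already Very Potent Core

The source may hold more compounds than are shown below. What is called first, only, known or untested is meant among the compounds shown, and "the series" means these compounds.

Compound 1 `Cc1cc(N)ccc1-c1nc2ccccc2s1`, compound 2 `CCc1cc(N)ccc1-c1nc2ccccc2s1` and compound 3 `Nc1ccc(-c2nc3ccccc3s2)c(Br)c1` share one core and differ at a single aromatic carbon. In a functional assay on MCF7 cells (Homo sapiens) for inhibition (a lower number here means a stronger inhibitor, a higher number a weaker inhibitor), compound 1 gives < 0.1 nM; < 0.1 nM (2 entries). In this assay compound 2 gives < 0.1 nM, a limit of the assay rather than a number. Compound 3 gives < 0.1 nM, also a limit, so its true standing is not pinned down. The step that the two limits leave unreadable from compound 2 to compound 3 cannot be sized because of the limit of < 0.1 nM in this assay, at which 2 of the 3 values shown sit. Compound 4 `Cc1ccc2nc(-c3ccc(N)cc3Br)sc2c1` differs from compound 3 by methyl in place of hydrogen on an aromatic carbon. With every measured value at the limit and no readable step, the step of a number no lower from compound 3 to compound 4 (the limit leaves the size open) is expected to stay within the scatter. Compound 4 is therefore estimated at 0.1 nM, within 0.02 nM to 0.5 nM, and may again be reported only as a limit.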

Compound 4, half-maximal inhibitory concentration: < 0.1 nM
Compound 4 was reported as a limit (the forecaster's own chance of this, stated with the estimate: 60%); the middle value lies on the limit itself.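

The step from compound 3 to compound 4 cannot be sized, because both results are limits of the assay and not numbers: the limit of < 0.1 nM in this assay, at which 3 of the 4 values shown sit.

From the compounds shown here alone, how strongly these compounds truly inhibit, and whether methyl in place of hydrogen changes that at all, stays open.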